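Hydrazone aryl swaps on a shared urea core

The source may hold more compounds than are shown below. What is called first, only, known or untested is meant among the compounds shown, and "the series" means these compounds.

Working notes on the series, read in a functional assay on NCI-H460 cells (Homo sapiens) for cytotoxicity, read by MTT assay, with a stated time of 72 h; on this read-out lower numbers stand for stronger inhibition and higher numbers for weaker inhibition. Compound 1 `CN(C)CCn1cnnc1-c1cc(Oc2ccc(NC(=O)N/N=C/c3c[nH]c4ccccc34)cc2F)ccn1` gives 1630 nM. Compound 2 `CN(C)CCn1cnnc1-c1cc(Oc2ccc(NC(=O)N/N=C/c3c(O)ccc4ccccc34)cc2F)ccn1` gives 890 nM. Among the measured compounds shown here, on these two numbers compound 2 carries the lowest value, with compound 1 the nearest; the single measured step, a 1.8-fold lower number from compound 1 to compound 2 (0.26 log units; within the scatter), came with 2-hydroxynaphthalen-1-yl in place of 1H-indol-3-yl on the carbon with a double bond to nitrogen, and that step stays inside the scatter.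

Compound 3 `COc1ccc(/C=N/NC(=O)Nc2ccc(Oc3ccnc(-c4nncn4CCN(C)C)c3)c(F)c2)cc1O` remains to be measured in this assay. Its change from compound 2 is 3-hydroxy-4-methoxyphenyl in place of 2-hydroxynaphthalen-1-yl on a carbon with a double bond to nitrogen, again an exchange of the aryl group on the carbon with a double bond to nitrogen. For the measured compounds named here, the only step that bears on it is the one between compound 1 and compound 2, and that step did not clear the scatter, so for compound 3 the expected step is a 1.3-fold higher number from compound 2 to compound 3 (0.13 log units; within the scatter), that is, nothing beyond the scatter in either direction. The estimate for compound 3 in this assay is therefore 1200 nM, with an expected range from 450 nM to 3200 nM.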

Compound 3, half-maximal inhibitory concentration: 620 nM
The estimate for compound 3 lay 1.9-fold (0.29 log units) above the measured number, and the stated range covers the measured number.
By their numbers in this assay, from the lowest: compounds 3, 2 and 1 (each within the scatter of the next, the first and the last beyond it).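

In this assay, the 3-hydroxy-4-methoxyphenyl group on the carbon with a double bond to nitrogen keeps pace with 2-hydroxynaphthalen-1-yl, with a 1.4-fold lower number from compound 2 to compound 3 (0.16 log units; within the scatter), so a second six-membered aromatic ring of carbon is not required at this position for a number at this level. Among the compounds shown here, the only step at this position beyond the scatter is a 2.6-fold lower number from compound 1 to compound 3 (0.42 log units; beyond the scatter), which comes with 3-hydroxy-4-methoxyphenyl in place of 1H-indol-3-yl, while compound 2 remains within the scatter of both other compounds and so cannot be placed in order against either. No measurement on hand accounts for these differences.

The compounds shown leave open whether the hydroxyl or the methoxy group of compound 3 contributes to its separation from compound 1, a question that an unsubstituted phenyl, a 3-hydroxyphenyl and a 4-methoxyphenyl on the same carbon would address. They also leave open how this position responds to an aryl group carrying an amine or a carboxylic acid, and whether a six-membered aromatic ring containing nitrogen, such as pyridinyl, would fit the same range.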